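The source may report more compounds than this note shows. Statements on the series, on what has been measured and on what is new or still open speak of the compounds shown alone.

Measured so far:
compound 1 `CC(=O)c1ccc(OCc2ccc([N+](=O)[O-])cc2)cc1` gives 96.5 nM
compound 2 `CC(=O)c1cccc(OCc2cccc(Cl)c2)c1` gives 34.2 nM

In an assay on isolated protein for inhibition of Amine oxidase [flavin-containing] B (Homo sapiens), read by Amplex Red, with a stated time of 15 min (a lower number here means a stronger inhibitor, a higher number a weaker inhibitor), compound 2 holds the lowest of the two numbers; its nearest neighbour, compound 1, gives 96.5 nM, a gap that lies beyond the usual scatter. Compound 3 `CC(=O)c1cccc(OCc2cccc(C(F)(F)F)c2)c1` has not been measured. It differs from compound 2 in one place: trifluoromethyl in place of chloro on an aromatic carbon. For the measured compounds named here, no step between measured compounds corresponds to this change, so its size cannot be read from the two values at hand. The remainder of the structure is unchanged, so the expected step in this assay is small, in either direction, and most likely not beyond the scatter. Compound 3 is therefore expected to give about 40 nM in this assay, with a range from 12 nM to 130 nM. The estimated step from compound 2 to compound 3 is a 1.2-fold higher number from compound 2 to compound 3 (0.07 log units; within the scatter).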

Compound 3, half-maximal inhibitory concentration: 21.2 nM
Compound 3: the middle estimate sits 1.9-fold (0.28 log units) above what was measured, and the stated range covers the measured number.
By their numbers in this assay, from the lowest: compounds 3 and 2 (each within the scatter of the next); then compound 1.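

In this assay, for the compounds shown here, trifluoromethyl in place of chloro on an aromatic carbon, meta to a large group, gives a 1.6-fold lower number from compound 2 to compound 3 (0.21 log units; within the scatter), the only step that can be read so far. At this position, then, a group of four heavy atoms and a group of one heavy atom cannot be told apart in this assay, which the comparison of compound 1 with compound 2 could not show because those two differ in more than one place. Nothing at hand bears on why the two groups read alike.

On these data alone, whether the position tolerates other kinds of group, such as an amine, a carboxylic acid or a longer alkyl chain, stays open. Also open, as far as these compounds go, is whether the same exchange of chloro for trifluoromethyl would read alike at another place on that ring.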